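This account rests on a few compounds, and the source may have more. Where it says the series, first, only, none or still open, it means among the compounds named here.

Within the data shown here, in an ADME assay on HEK-293T cells (Homo sapiens) for cytotoxicity, read by CCK-8 assay, with a stated time of 48 h (on this read-out lower numbers stand for stronger inhibition and higher numbers for weaker inhibition), compound 2 `O=C(Nc1ccc(F)cc1)N1CCN(S(=O)(=O)c2sccc2-c2ccccc2Oc2ccc(O)c(O)c2)CC1` gives 15500 nM, the only actual number among the compounds read so far, so it cannot yet be ranked against a measured neighbour. Compound 3 `O=[N+]([O-])c1ccc(NC(=S)N2CCN(S(=O)(=O)c3sccc3-c3ccccc3Oc3ccc(O)c(O)c3)CC2)cc1` keeps the core of compound 2 and changes only on an amine nitrogen in a ring, where the (4-fluorophenyl)carbamoyl group leaves: a group of 12 heavy atoms (7 carbon, 2 nitrogen, 2 oxygen, 1 sulfur; one six-membered aromatic ring of carbon only) in place of a group of 10 heavy atoms (7 carbon, 1 nitrogen, 1 oxygen, 1 fluorine; one six-membered aromatic ring of carbon only), on an amine nitrogen in a ring. Among the measured compounds shown here, no measured step isolates this change. Compound 1 `COc1ccc(Oc2ccccc2-c2ccsc2S(=O)(=O)N2CCN(C(=S)Nc3ccc([N+](=O)[O-])cc3)CC2)cc1OC` carries the entering group and gives > 20000 nM, which is a limit of the assay, so a small step toward weaker inhibition in this assay, perhaps none beyond the scatter, is expected. The estimated change is a 1.2-fold higher number from compound 2 to compound 3 (0.06 log units; within the scatter). Compound 3 is expected to read about 18000 nM, with an estimated range of 8000 nM to 40000 nM, and the assay may report only a limit for it.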

Compound 3, half-maximal inhibitory concentration: > 20000 nM
Compound 3 gave a limit, no number; the forecaster's own chance of this, stated with the estimate: 45%; middle value at least 1.1-fold (0.04 log units) away from the limit.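

In this assay, among these compounds, the group of 12 heavy atoms that replaces (4-fluorophenyl)carbamoyl on the amine nitrogen in the ring gives an at least 1.2-fold higher number from compound 2 to compound 3 (0.11 log units; that floor lies within the scatter), the only readable step at this position. This step is a floor, so it shows no change beyond the scatter, yet it does not rule one out. Compound 3 reads as a limit and not as a number, and the step between compound 1 and compound 3, 3,4-dihydroxyphenyl in place of 3,4-dimethoxyphenyl, cannot be read: the limit of > 20000 nM in this assay, at which 2 of the 3 values shown sit.

Still open, as far as these compounds go, is how far compound 3 lies past its limit in this assay. Also open, from the compounds shown here alone, is whether an acetyl group or a longer alkyl chain on the same ring nitrogen would give a measurable number.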